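The compounds below may be only part of what the source reports. "The series", "measured", "known", "first", "only" and "open" are said of these compounds alone.

In a functional assay, with a stated time of 10 min (on this read-out higher numbers stand for weaker inhibition and lower numbers for stronger inhibition), three compounds that share a core have been measured so far. Compound 1 `CCCCCCOc1cc(OC)c(Br)cc1C(C)=O` gives 53100000 nM, compound 2 `CCOc1cc(OC)ccc1C(C)=O` gives 35300000 nM, and compound 3 `CCCCOc1cc(OC)ccc1C(C)=O` gives 57200000 nM. Compound 3 lies within the scatter of both others, meaning the gaps are no larger than repeat measurements normally differ, and it sits closest to compound 1. These numbers therefore set no firm order among the three.

Compound 4 `CCCCCCOc1cc(OC)ccc1C(C)=O` differs from compound 3 by one change, ethyl in place of hydrogen on a saturated chain carbon, four bonds along the chain from an oxygen on an aromatic ring. Among the measured compounds shown here, the one measured step that bears on this is the same swap made two bonds along the chain, a 1.6-fold higher number from compound 2 to compound 3 (0.21 log units; within the scatter). That step did not rise above the scatter, so no clear shift in either direction is expected here. The expected change is a 1.0-fold lower number from compound 3 to compound 4 (0.02 log units; within the scatter), which would stay within the scatter. For compound 4 the estimate is 55000000 nM, with an expected range from 28000000 nM to 110000000 nM.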

Compound 4, half-maximal inhibitory concentration: 84400000 nM
The estimate for compound 4 lay 1.5-fold (0.19 log units) below the measured number; measured number inside the range.
By their numbers in this assay, from the lowest: compounds 2, 1, 3 and 4 (each within the scatter of the next, the first and the last beyond it).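

In this assay, among the compounds shown here, the added ethyl four bonds along the chain gives a 1.5-fold higher number from compound 3 to compound 4 (0.17 log units; within the scatter) and stays within the scatter on its own, but the longer butyl change made two bonds along the chain gives a 2.4-fold higher number from compound 2 to compound 4 (0.38 log units; beyond the scatter) and is the first modest step beyond the scatter, towards weaker inhibition. Hydrogen in place of bromo on the aromatic carbon gives a 1.6-fold higher number from compound 1 to compound 4 (0.20 log units; within the scatter) and also stays within the scatter, so this pair shows no clear effect of the bromo. Nothing measured here explains why the longer chain goes with the higher number.

As far as these compounds go, whether a chain longer than that of compound 4 would raise the number further remains open. So does the effect of an amine or a carboxylic acid on that chain.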